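Replacing the 6-(hydroxycarbamoyl)hexyl group of compound 2

This account rests on a few compounds, and the source may have more. Where it says the series, first, only, none or still open, it means among the compounds named here.

Two compounds have readings so far. In a functional assay on HCT-116 cells (Homo sapiens) for inhibition, read by MTT assay, with a stated time of 72 h (a higher number here means a weaker inhibitor, a lower number a stronger inhibitor), compound 1 (`CC(C)CCN(CCCCCCC(=O)NO)c1ncc(C(=O)NCc2cccnc2)s1`) gives 12000 nM and compound 2 (`O=C(CCCCCCCN(Cc1ccc(F)cc1)c1ncc(C(=O)NCCCn2ccnc2)s1)NO`) gives 63000 nM as its reading. Compound 2 therefore stands highest of the two and is the weaker inhibitor, with a gap beyond the usual scatter. The two compounds differ in more than one place, so that gap cannot be tied to a single group. Compound 3 (`O=C(/C=C/c1ccc(CN(Cc2ccc(F)cc2)c2ncc(C(=O)NCCCn3ccnc3)s2)cc1)NO`) carries 4-(2-(hydroxycarbamoyl)ethenyl)phenyl in place of 6-(hydroxycarbamoyl)hexyl on a saturated chain carbon bound to a nitrogen on an aromatic ring. Among the measured compounds shown here, no measured pair shows this change, so the expectation remains loose. Starting from compound 2 at 63000 nM as the higher number, a fall beyond the scatter in this assay is expected, toward stronger inhibition. The expected step runs a 7.9-fold lower number from compound 2 to compound 3 (0.90 log units; beyond the scatter) as a rough figure. Compound 3 is estimated at 8000 nM (range 1500 nM to 40000 nM).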

Compound 3, half-maximal inhibitory concentration: 83000 nM
For compound 3 the middle estimate is 10-fold (1.02 log units) below the measured one; measured number outside the range, above it.
By their numbers in this assay, from the lowest: compound 1; then compounds 2 and 3 (each within the scatter of the next).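

In this assay, among the compounds shown here, the first one-place comparison is (a 1.3-fold higher number from compound 2 to compound 3 (0.12 log units; within the scatter)), with 4-(2-(hydroxycarbamoyl)ethenyl)phenyl in place of 6-(hydroxycarbamoyl)hexyl on a saturated chain carbon bound to a nitrogen on an aromatic ring. At this place the two groups read alike on the background of compound 2, so the entering aromatic ring and extra double bond bring no measurable gain in this cell read-out. No evidence at hand bears on this result.

Still open, from the compounds shown here alone, is whether a longer chain carrying the hydroxycarbamoyl group, or a carboxylic acid in place of the hydroxycarbamoyl end, would read differently at this place. The other groups on the shared core that separate compound 1 from compound 2 also have no one-place comparison yet.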